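This account rests on a few compounds, and the source may have more. Where it says the series, first, only, none or still open, it means among the compounds named here.

Compound 1 `CNC(=O)c1sc(N2CC3CC2(CNC(=O)c2c[nH]c4ncc(C(F)(F)F)cc24)C3)nc1C(F)(F)F` in an ADME assay on cells (Hepatocyte, Rattus norvegicus) for metabolic stability (a lower number here means slower removal, a higher number faster removal of the compound), gives 78 uL/min.
Compound 2 `CNC(=O)c1sc(N2CC3CC2(CNC(=O)c2c[nH]c4ncccc24)C3)nc1C(F)(F)F` in this assay gives 33 uL/min.

Among the measured compounds shown here, compound 2 has the lowest of the two numbers in this assay; its only neighbour is compound 1, and the step of a 2.4-fold lower number from compound 1 to compound 2 (0.37 log units; beyond the scatter) lies beyond the scatter and is modest in size. Compound 3 `CNC(=O)c1sc(N2CC3CC2(CNC(=O)c2c[nH]c4ncc(C)cc24)C3)nc1C(F)(F)F` has not yet been measured in this assay. It differs from compound 2 in one place: methyl in place of hydrogen on an aromatic carbon.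

For the measured compounds named here, only one measured step bears on this change, the step of a 2.4-fold lower number from compound 1 to compound 2 (0.37 log units; beyond the scatter), which concerns the same position on the same ring but a different group, trifluoromethyl rather than methyl. Going by the values given here, that step is the sole guide here, and its direction suggests that a group at this position goes with a higher number than hydrogen, without telling how far a methyl follows the trifluoromethyl. A step from compound 2 to compound 3 of the size a 1.4-fold higher number from compound 2 to compound 3 (0.13 log units; within the scatter) toward a higher number is therefore expected, likely smaller than the step between compound 1 and compound 2 and possibly not beyond the scatter. For compound 3 in this assay the estimate is 45 uL/min, with a range from 25 uL/min to 85 uL/min.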

Compound 3, intrinsic clearance in a liver preparation (reported as CLH), per the amount of preparation that the assay uses in the Hepatocyte assay: 92 uL/min
Estimate against measurement, compound 3: 2.0-fold (0.31 log units) below, outside the stated range (above it).
By their numbers in the Hepatocyte assay, from the lowest: compound 2; then compounds 1 and 3 (each within the scatter of the next).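

In the Hepatocyte assay, methyl at this position does not sit part-way between hydrogen and trifluoromethyl: the step is a 2.8-fold higher number from compound 2 to compound 3 (0.45 log units; beyond the scatter), whereas the change from trifluoromethyl to methyl gives a 1.2-fold higher number from compound 1 to compound 3 (0.07 log units; within the scatter). Methyl and trifluoromethyl are thus not separated in this assay, and both stand apart from hydrogen, so the higher number seen earlier is not specific to trifluoromethyl among these three compounds. In a physicochemical assay for lipophilicity, at pH 7.4 (a lower number here means a more polar compound, a higher number a more lipophilic compound), compound 2 gives 3.1 and compound 3 gives 3.5, so faster removal may be linked to higher lipophilicity for this one pair, although a single pair cannot establish the link: the measured distribution coefficient of compound 2, 3.1, and of compound 3, 3.5, a number 0.40 log units higher (beyond the scatter).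

The compounds shown give both read-outs only for compound 2 and compound 3, so they leave open whether the number in the Hepatocyte assay follows lipophilicity across the series or simply the presence of a group at this position. From the compounds shown here alone, whether a hydroxymethyl, a nitrile or an amine at the same aromatic carbon would bring the number back towards that of compound 2 also remains open.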